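A Chloropyridine Swapped for Benzene on a Hydrazide Core

The compounds below may be only part of what the source reports. "The series", "measured", "known", "first", "only" and "open" are said of these compounds alone.

Going by the values given here, compound 1 `COc1ccc(-c2cc(C(=O)N/N=C/c3ccccc3O)n(Cc3ccc(Cl)nc3)n2)cc1` is one of three compounds measured in a physicochemical assay on A549 cells for solubility, read by microscopy, with a stated time of 24 h; on this read-out higher numbers stand for weaker inhibition and lower numbers for stronger inhibition; in it compound 1 gives 570 nM. Its two companions keep the same core and change only the ring attached to the carbon that carries a double bond to nitrogen. Compound 2 `COc1ccc(/C=N/NC(=O)c2cc(-c3ccc(OC)cc3)nn2Cc2ccc(Cl)nc2)cc1` gives 18900 nM and compound 3 `COc1ccc(-c2cc(C(=O)N/N=C/c3ccco3)n(Cc3ccc(Cl)nc3)n2)cc1` gives 15800 nM. Both steps away from compound 1 are large: a 33-fold higher number from compound 1 to compound 2 (1.52 log units; beyond the scatter) and a 28-fold higher number from compound 1 to compound 3 (1.44 log units; beyond the scatter). Compound 1 therefore stands lowest of the three by a wide margin, while its two companions differ from each other by only a 1.2-fold lower number from compound 2 to compound 3 (0.08 log units; within the scatter).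

Compound 4 `COc1ccc(-c2cc(C(=O)N/N=C/c3ccccc3O)n(Cc3ccccc3)n2)cc1` is not yet measured. It differs from compound 1 at a different place: phenyl in place of 6-chloropyridin-3-yl on a saturated chain carbon bound to an aromatic nitrogen. Among the compounds with values here, none of the measured steps touches that part of the molecule; all three alter the ring on the carbon with the double bond to nitrogen. Within the data shown here, no measured step bears on this change, so the expectation can only be that the number stays near where compound 1 sits, with wide uncertainty. For compound 4 the expected result is 800 nM, within 250 nM to 2500 nM. This corresponds to an expected step of a 1.4-fold higher number from compound 1 to compound 4 (0.15 log units; within the scatter), likely within the scatter.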

Compound 4, half-maximal inhibitory concentration: 840 nM
The estimate for compound 4 lay 1.1-fold (0.02 log units) below the measured number; low and high end bracket the measured number.
By their numbers in this assay, from the lowest: compounds 1 and 4 (each within the scatter of the next); then compounds 3 and 2 (each within the scatter of the next).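

Replacing 6-chloropyridin-3-yl with phenyl on a saturated chain carbon bound to an aromatic nitrogen gives in this assay a 1.5-fold higher number from compound 1 to compound 4 (0.17 log units; within the scatter) and so leaves the two compounds indistinguishable. This is the only step shown at this position, and it shows that the chlorine, the ring nitrogen and the hydrogen-bond acceptor counted with them can all leave in one swap without a step beyond the scatter, at least while the 2-hydroxyphenyl stays in place. The contrast lies with the ring on the carbon with a double bond to nitrogen, where the steps shown are large: a 33-fold higher number from compound 1 to compound 2 (1.52 log units; beyond the scatter) and a 28-fold higher number from compound 1 to compound 3 (1.44 log units; beyond the scatter).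

Nothing shown gives a reason for the lack of a clear step at this position. As far as these compounds go, it also remains open whether the chlorine and the ring nitrogen would each matter alone, and whether benzyl could give way to a longer chain such as 2-phenylethyl, or to a ring bearing an amine or a carboxylic acid, without a step beyond the scatter.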